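A few compounds are considered here, and "the series" means these few. Any claim that something is new, unique, unknown or untested is made for them only; others in the source may bear on it.

Compounds measured so far in an in vitro functional assay on cells for agonist activity at Bombesin receptor subtype-3 (Homo sapiens), read by luminescence and calcium flux; on this read-out higher numbers stand for an effect only at larger amounts of compound and lower numbers for an effect already at smaller amounts:
- compound 1, `COc1ccc(Cc2cnc(CCc3ccc(-c4ccccc4C(=O)O)cc3)[nH]2)cc1`, gives 5360 nM
- compound 2, `Cc1cccc(Cc2cnc(CCc3ccc(-c4ccccc4C(=O)O)cc3)[nH]2)c1`, gives 4310 nM
- compound 3, `CCCCc1cnc(CCc2ccc(-c3ccccc3C(=O)O)cc2)[nH]1`, gives 2710 nM

Compound 1 stands at the highest of the three numbers, yet each of its two neighbours sits within the usual scatter of it: the step to compound 2 is a 1.2-fold lower number from compound 1 to compound 2 (0.09 log units; within the scatter) and the step to compound 3 is a 2.0-fold lower number from compound 1 to compound 3 (0.30 log units; within the scatter). The step between the other two, a 1.6-fold lower number from compound 2 to compound 3 (0.20 log units; within the scatter), is likewise within the scatter. On these numbers the three compounds cannot be told apart.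

Compound 4, `Cc1ccc(Cc2cnc(CCc3ccc(-c4ccccc4C(=O)O)cc3)[nH]2)cc1`, is the next compound to be tested. It differs from compound 1 in one place: methyl in place of methoxy on an aromatic carbon.

Going by the values given here, the step most closely related is the one from compound 1 to compound 2, where a methyl-bearing ring also replaced the methoxyphenyl ring and the number moved by a 1.2-fold lower number from compound 1 to compound 2 (0.09 log units; within the scatter). The larger exchange to a propyl chain, a 2.0-fold lower number from compound 1 to compound 3 (0.30 log units; within the scatter), also stayed within the scatter. A change as small as methyl for methoxy is therefore expected to give no step beyond the scatter in this assay, perhaps a slightly lower number.

The estimate for compound 4 is 4500 nM, within a range of 2200 nM to 9000 nM, which means an expected step of a 1.2-fold lower number from compound 1 to compound 4 (0.08 log units; within the scatter).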

Compound 4, half-maximal effective concentration: 2660 nM
For compound 4 the middle estimate is 1.7-fold (0.23 log units) above the measured one; measured number inside the range.
By their numbers in this assay, from the lowest: compounds 4, 3, 2 and 1 (each within the scatter of the next).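

In this assay, methyl in place of methoxy on the aromatic carbon para to a large group gives a 2.0-fold lower number from compound 1 to compound 4 (0.30 log units; within the scatter) and so compares two groups directly at this ring carbon, with the rest of the molecule unchanged; in the count of the two groups, this takes away one oxygen and one hydrogen-bond acceptor without taking the number beyond the scatter. Moving the methyl on the ring gives a 1.6-fold lower number from compound 2 to compound 4 (0.21 log units; within the scatter) and replacing the propyl of compound 3 with 4-methylphenyl gives a 1.0-fold lower number from compound 3 to compound 4 (0.01 log units; within the scatter), so neither the methyl's location nor an aromatic ring in place of a saturated chain separates these compounds. With compound 4 included, all four compounds still cannot be told apart in this assay, and no firm preference for any of these groups can be drawn from their numbers.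

Still open, from the compounds shown here alone, is whether a different group on this ring carbon, such as a hydroxyl or an amine, would give a step beyond the scatter. The data shown offer no measurement that explains these numbers.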